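An Ester Carried Further Out Along the Chain of Compound 1

This account rests on a few compounds, and the source may have more. Where it says the series, first, only, none or still open, it means among the compounds named here.

Three compounds have so far been measured in an assay on isolated protein (Oryctolagus cuniculus) with Thromboxane-A synthase (Homo sapiens) as the target, tested at 1 uM; a lower number here means less inhibition, a higher number more inhibition at the concentration tested (going by the name of the read-out):

compound 1, `CCCCn1nc(-c2cccnc2)c2ccccc2c1=O`, 91%
compound 2, `COCCn1nc(-c2cccnc2)c2ccccc2c1=O`, 55%
compound 3, `CCOC(=O)Cn1nc(-c2cccnc2)c2ccccc2c1=O`, 28%

Compound 1 stands highest of the three in this assay. Its nearest neighbour is compound 2, with the step of a number 36 percentage points lower from compound 1 to compound 2 (beyond the scatter), and the furthest is compound 3, with the step of a number 63 percentage points lower from compound 1 to compound 3 (beyond the scatter). Between the other two, a number 27 percentage points lower from compound 2 to compound 3 (beyond the scatter).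

Compound 4, `CCOC(=O)CCCn1nc(-c2cccnc2)c2ccccc2c1=O`, has not yet been measured. It differs from compound 1 in one place: ethoxycarbonyl in place of methyl on a saturated chain carbon, three bonds along the chain from an aromatic nitrogen. Going by the values given here, two measured steps bear on this change. The step of a number 63 percentage points lower from compound 1 to compound 3 (beyond the scatter) puts an ethoxycarbonyl on the saturated chain carbon bound to the aromatic nitrogen; the step of a number 36 percentage points lower from compound 1 to compound 2 (beyond the scatter) puts a methoxy two bonds along the chain from the aromatic nitrogen. Both lowered the number, the first by more. In compound 4 the ethoxycarbonyl sits three bonds along the chain, further out than either, so a fall in this assay is expected, smaller than both measured steps yet probably beyond the scatter. For compound 4 the estimate is 65%, within 40% to 85%. The step this estimate implies is expected to be a number 26 percentage points lower from compound 1 to compound 4 (beyond the scatter).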

Compound 4, a percentage reported as inhibition, at one concentration (the size of the read-out at that concentration, not a potency): 95%
For compound 4 the middle estimate is 30 percentage points below the measured one, and the stated range ends below it.
By their numbers in this assay, from the lowest: compound 3; then compound 2; then compounds 1 and 4 (each within the scatter of the next).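

In this assay, the ethoxycarbonyl group three bonds along the chain from an aromatic nitrogen is accepted, with a number 4 percentage points higher from compound 1 to compound 4 (within the scatter), so adding this ester to the end of the butyl chain produces no change that can be distinguished from the scatter. The ester group therefore does not lower the number wherever it stands: with the ester carried further out along the chain, the result is a number 67 percentage points higher from compound 3 to compound 4 (beyond the scatter), which shows that its place on the chain matters greatly in this series. The fall seen with the methoxy group two bonds along the chain does not carry over to this longer ester-bearing chain either, as the comparison gives a number 40 percentage points higher from compound 2 to compound 4 (beyond the scatter).

No evidence is available to explain why the ester is accepted at this place on the chain and not on the saturated chain carbon bound to the aromatic nitrogen. From the compounds shown here alone, it remains open whether a carboxylic acid in place of the ethyl ester, an amine at the end of the chain, or a longer chain carrying the same ester would hold the number at this level.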